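Swapping the aryl on the piperazine of a benzamide

The source may report more compounds than this note shows. Statements on the series, on what has been measured and on what is new or still open speak of the compounds shown alone.

Measured compounds:
- compound 1, `Nc1ccccc1NC(=O)c1ccc(CSC(=S)N2CCN(c3ccc(Cl)cc3)CC2)cc1`: 32.2%
- compound 2, `CC1CCN(C(=S)SCc2ccc(C(=O)Nc3ccccc3N)cc2)CC1`: 32.7%
- compound 3, `Nc1ccccc1NC(=O)c1ccc(CSC(=S)N2CCN(c3ccncc3)CC2)cc1`: 85.7%

In a functional assay on A-375 cells (Homo sapiens) for antiproliferative activity, read by CCK-8 assay, with a stated time of 72 h, tested at 2 uM (on this read-out lower numbers stand for a weaker effect and higher numbers for a stronger effect at the one concentration tested), compound 1 gives the lowest of the three numbers; compound 2 lies within the scatter of it, while compound 3 stands far higher. Among the measured compounds shown here, the one step that touches this position, a number 53.5 percentage points higher from compound 1 to compound 3 (beyond the scatter), is large. Compound 4, `CN1CCN(C(=S)SCc2ccc(C(=O)Nc3ccccc3N)cc2)CC1`, differs from compound 1 in the same place: methyl in place of 4-chlorophenyl on an amine nitrogen in a ring. For the measured compounds named here, the same group leaves but a different one enters, so that step only loosely bears on the new one, and compound 2 offers no step. A moderate rise is expected, a number 12.8 percentage points higher from compound 1 to compound 4 (beyond the scatter), with wide uncertainty. The estimate for compound 4 is 45%, ranging from 20% to 75%.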

Compound 4, a percentage reported as inhibition, at one concentration (the size of the read-out at that concentration, not a potency): 36.6%
Beside the measured number, compound 4's estimate is 8.4 percentage points above it, and the stated range covers the measured number.
By their numbers in this assay, from the lowest: compounds 1, 2 and 4 (each within the scatter of the next); then compound 3.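

In this assay methyl in place of 4-chlorophenyl gives a number 4.4 percentage points higher from compound 1 to compound 4 (within the scatter) and so a single carbon on this ring nitrogen reads the same as the far larger aryl group. Methyl in place of pyridin-4-yl gives a number 49.1 percentage points lower from compound 3 to compound 4 (beyond the scatter) and this leaves pyridin-4-yl alone among the groups shown here. On the thiocarbonyl carbon, 4-methylpiperazin-1-yl in place of 4-methylpiperidin-1-yl gives a number 3.9 percentage points higher from compound 2 to compound 4 (within the scatter) and so that exchange also stays within the scatter. Nothing available explains why pyridin-4-yl stands apart. Whether the high number is particular to pyridin-4-yl stays open, since pyridin-3-yl or unsubstituted phenyl on the same nitrogen does not appear among these compounds.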